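The source may report more compounds than this note shows. Statements on the series, on what has been measured and on what is new or still open speak of the compounds shown alone.

Compound 1 `CC(C)(C)Nc1c(-c2ccccn2)nc2c(OCc3ccccc3)cccn12` gives > 50000 nM in an ADME assay on THP-1 cells (Homo sapiens) for cytotoxicity; a lower number here means that less compound is tolerated, a higher number that more compound is tolerated; this is a limit of the assay, not a number.
Compound 2 `c1ccc(-c2nc3ccccn3c2NCC2CC2)nc1` gives 19400 nM in this assay.
Compound 3 `Cc1ccn2c(Nc3ccccn3)c(-c3ccccn3)nc2c1` gives > 50000 nM in this assay; this too is a limit, not a number.

Compound 3 therefore stands at the upper edge of what this assay can report, together with compound 1, as the limit of > 50000 nM in this assay, at which 2 of the 3 values shown sit, shows; only compound 2 has a value that was actually resolved, and it lies inside the measured window.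

The unmeasured compound 4 `Cc1ccn2c(Nc3cccc(F)c3)c(-c3ccccn3)nc2c1` differs from compound 3 in one place: 3-fluorophenyl in place of pyridin-2-yl on a nitrogen on an aromatic ring. The shared core and everything else stay the same.

Within the data shown here, no measured pair in this set shows the effect of such a swap, so the size of the step from compound 3 to compound 4 in this assay is an open question. The expectation is a modest move toward a lower tolerated concentration, of roughly an at least 1.4-fold lower number from compound 3 to compound 4 (0.15 log units; that floor lies within the scatter), possibly no more than the usual scatter. Compound 4 is accordingly estimated at 35000 nM, within a range from 12000 nM to 100000 nM, with a fair chance that only a limit is reported again.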

Compound 4, half-maximal cytotoxic concentration: 14200 nM
Compound 4: the middle estimate sits 2.5-fold (0.39 log units) above what was measured; the range from low to high includes it.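

Among these compounds, putting 3-fluorophenyl in place of pyridin-2-yl on a nitrogen on an aromatic ring gives an at least 3.5-fold lower number from compound 3 to compound 4 (0.54 log units; beyond the scatter) in this assay and so shows, for the first time here, that a change at this position can move the tolerated concentration beyond the usual scatter. Compound 3 gives > 50000 nM as a limit of the assay and not a number. Going by these compounds, the step is therefore only a floor, and its full size stays unknown because compound 3 sits at that limit: the limit of > 50000 nM in this assay, at which 2 of the 4 values shown sit.

On these data alone, whether the step comes from the loss of the ring nitrogen or from the gain of the fluorine stays open. A plain phenyl group on the same nitrogen would separate the two, and the compounds shown do not tell how it would behave.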